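The compounds below may be only part of what the source reports. "The series", "measured", "known", "first", "only" and "open" are said of these compounds alone.

Measured compounds:
Compound 1 `CCc1cc(/C=C/C(=O)c2ccccc2NC(=O)NS(=O)(=O)c2ccc(C)cc2)cc(OC)c1OC` gives 19.2 ug/mL in an ADME assay on the whole organism for cytotoxicity, with Artemia salina as the target, with a stated time of 24 h; on this read-out lower numbers stand for an effect already at smaller amounts and higher numbers for an effect only at larger amounts of compound.
Compound 2 `Cc1ccc(S(=O)(=O)NC(=O)Nc2ccccc2C(=O)/C=C/c2ccc(O)cc2)cc1` gives 24.3 ug/mL in this assay.

Only these two numbers are known so far. Compound 2 has the higher of the two, but the step of a 1.3-fold higher number from compound 1 to compound 2 (0.10 log units; within the scatter) shows that the two compounds cannot be told apart on this read-out; the larger aromatic group of compound 1 and the smaller hydroxy-bearing ring of compound 2 gave the same outcome within measurement noise.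

Compound 3 `CCOc1cc(/C=C/C(=O)c2ccccc2NC(=O)NS(=O)(=O)c2ccc(C)cc2)ccc1O` keeps the whole of compound 2 and differs in one spot: ethoxy in place of hydrogen on an aromatic carbon. Going by the values given here, the only measured step, a 1.3-fold higher number from compound 1 to compound 2 (0.10 log units; within the scatter), altered the same ring far more drastically and still stayed within the scatter, so a single added ethoxy group is expected to leave the number essentially unchanged. Compound 3 is therefore estimated at 22 ug/mL, with a range from 11 ug/mL to 45 ug/mL, corresponding to an expected step of a 1.1-fold lower number from compound 2 to compound 3 (0.04 log units; within the scatter).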

Compound 3, concentration for half-maximal effect: 19.2 ug/mL
Compound 3: the middle estimate sits 1.1-fold (0.06 log units) above what was measured; the range from low to high includes it.
By their numbers in this assay, from the lowest: compounds 1, 3 and 2 (each within the scatter of the next).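

In this assay, the step of a 1.3-fold lower number from compound 2 to compound 3 (0.10 log units; within the scatter) shows that this aromatic carbon, ortho to a hydroxy group, can carry an ethoxy group with no change that can be told from the scatter. The step of no change at the digits printed from compound 1 to compound 3 (within the scatter) adds that 3-ethoxy-4-hydroxyphenyl and 3-ethyl-4,5-dimethoxyphenyl cannot be told apart either, so all three ring patterns shown lie within the scatter of one another. No evidence is available to explain this outcome.

From the compounds shown here alone, it remains open whether any group at this position would move the number, for example an amine, a carboxylic acid, or a longer chain in place of ethoxy. Going by these compounds, it is also open whether changes elsewhere in the shared core would matter more than changes on this ring.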